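Swapping the Thiazole for Phenyl on the Amide Nitrogen

The compounds below may be only part of what the source reports. "The series", "measured", "known", "first", "only" and "open" are said of these compounds alone.

Compound 3 `Cc1ccc(OCC(=O)N(Cc2cccs2)c2nccs2)cc1` gives the highest number of the three measured compounds in an assay on HEK293 cells for agonist activity at transient receptor potential cation channel subfamily M member 8 (Homo sapiens), read by fluorescence and calcium flux, with a stated time of 15 min (a lower number here means that less compound is needed, a higher number that more compound is needed for the effect), at 2240 nM. Its nearest neighbour is compound 2 `CCN(Cc1cccs1)C(=O)COc1ccc(F)cc1`, which in this assay gives 422 nM, and the furthest is compound 1 `CCN(Cc1cccs1)C(=O)COc1ccc(C)cc1`, which in this assay gives 8 nM. The change to compound 4 `Cc1ccc(OCC(=O)N(Cc2cccs2)c2ccccc2)cc1` is phenyl in place of 1,3-thiazol-2-yl on an amide-type nitrogen. Going by the values given here, no measured step makes this exact change. The closest comparison is a 280-fold higher number from compound 1 to compound 3 (2.45 log units; beyond the scatter), which shows that an aromatic ring on the amide-type nitrogen carries a heavy cost relative to ethyl. The other measured step, a 53-fold higher number from compound 1 to compound 2 (1.72 log units; beyond the scatter), concerns a different place and does not bear directly on this change. Since compound 4 also carries an aromatic ring on the amide-type nitrogen, its number is expected to stay near that of compound 3, with the direction uncertain. The estimated step is therefore a 1.5-fold lower number from compound 3 to compound 4 (0.17 log units; within the scatter), not beyond the scatter. Compound 4 is expected to give 1500 nM in this assay, within a range of 300 nM to 8000 nM.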

Compound 4, half-maximal effective concentration: 23 nM
For compound 4 the middle estimate is 65-fold (1.81 log units) above the measured one; the measured number lies below the stated range.
By their numbers in this assay, from the lowest: compound 1; then compound 4; then compound 2; then compound 3.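

The result shows that an aromatic ring on the amide-type nitrogen does not by itself carry the heavy penalty that compound 3 seemed to indicate: in this assay the change gives a 97-fold lower number from compound 3 to compound 4 (1.99 log units; beyond the scatter), so among these compounds the high number goes with the 1,3-thiazol-2-yl group and not with every aromatic ring at this place. Phenyl also comes close to ethyl, though not level with it, with a 2.9-fold higher number from compound 1 to compound 4 (0.46 log units; beyond the scatter), which is a modest step and still beyond the scatter. No measurement shown here explains why these two aromatic rings differ so widely at this place.

The compounds shown leave open whether a pyridin-2-yl ring on this nitrogen would track phenyl or 1,3-thiazol-2-yl. They also leave open how a methoxy group or a carboxylic acid on the phenyl ring would change the number.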